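Thiourea benzimidazoles on HeLa cells: methyl to isopropyl

The source may report more compounds than this note shows. Statements on the series, on what has been measured and on what is new or still open speak of the compounds shown alone.

Measured compounds:
compound 1 `C[C@@H](NC(=S)NCc1ccccc1)c1nc2ccccc2[nH]1` — "not active" (no number reported)
compound 2 `C[C@@H](NC(=S)Nc1cc(C(F)(F)F)cc(C(F)(F)F)c1)c1nc2ccccc2[nH]1` — 16100 nM
compound 3 `C[C@@H](NC(=S)Nc1ccccc1)c1nc2ccccc2[nH]1` — 12400 nM

In a functional assay on HeLa cells (Homo sapiens) for cytotoxicity, read by MTT assay (on this read-out higher numbers stand for weaker inhibition and lower numbers for stronger inhibition), compound 1 is reported as "not active" (no number reported), with no number attached, so it cannot be placed on a scale against the others. In this assay compound 2 gives 16100 nM, and compound 3 gives 12400 nM; these two values lie within the usual scatter of each other, and both stand at the weak end of the read-out. Compound 1 thus sits at or beyond the weak end alongside them.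

Compound 4 `CC(C)[C@@H](NC(=S)NCc1ccccc1)c1nc2ccccc2[nH]1` differs from compound 1 in one place: isopropyl in place of methyl on a saturated chain carbon bound to an amide-type nitrogen and an aromatic carbon. Among the compounds with values here, with no measured pair to show what this change does in this assay, and with compound 1 reported as "not active" (no number reported), the step is expected to be small, probably none beyond the scatter, with a real chance that compound 4 is again returned without a number. Compound 4 is expected to give about 25000 nM in this assay, somewhere between 8000 nM and 80000 nM.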

Compound 4, half-maximal inhibitory concentration: 12300 nM
Beside the measured number, compound 4's estimate is 2.0-fold (0.31 log units) above it; the measured number falls inside the stated range.
By their numbers in this assay, from the lowest: compounds 4, 3 and 2 (each within the scatter of the next).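

Within the data shown here, compound 1 is reported without a number, so no step from it to compound 4 can be read. The compounds shown leave open what isopropyl in place of methyl does on its own. No evidence at hand bears on this result.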